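The compounds below may be only part of what the source reports. "The series", "measured", "known", "first", "only" and "open" are said of these compounds alone.

Three compounds share one core and differ only in the group attached to a saturated chain carbon bound to a double-bonded chain carbon. Compound 1 `C=C[C@]1(C)CC[C@@H](C(=C)COCC)C[C@H]1C(=C)C` carries an ethoxy group there, compound 2 `C=C[C@]1(C)CC[C@@H](C(=C)COC)C[C@H]1C(=C)C` a methoxy, and compound 3 `C=C[C@]1(C)CC[C@@H](C(=C)CN(CC)CC)C[C@H]1C(=C)C` a diethylamino. In a functional assay on HeLa cells (Homo sapiens) for antiproliferative activity, read by WST assay, with a stated time of 24 h (on this read-out higher numbers stand for weaker inhibition and lower numbers for stronger inhibition), compound 1 gives 106000 nM, compound 2 gives 212000 nM and compound 3 gives 14400 nM. Compound 2 sits at the high end of the three, but the gap a 2.0-fold higher number from compound 1 to compound 2 (0.30 log units; within the scatter) lies within the scatter, so compound 1 and compound 2 cannot be told apart; the gap a 15-fold lower number from compound 2 to compound 3 (1.17 log units; beyond the scatter) is clearly beyond it, as is a 7.4-fold lower number from compound 1 to compound 3 (0.87 log units; beyond the scatter).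

Compound 4 `C=C[C@]1(C)CC[C@@H](C(=C)COCCOC)C[C@H]1C(=C)C` changes compound 2 in one place: methoxymethyl in place of hydrogen on a saturated chain carbon bound to an oxygen on a saturated carbon. For the measured compounds named here, the only measured step that bears on this is the change of the ether chain, a 2.0-fold higher number from compound 1 to compound 2 (0.30 log units; within the scatter), which stayed within the scatter. A longer ether chain is therefore expected to leave the number near where compound 2 stands, or move it only slightly lower, with the step of a 1.6-fold lower number from compound 2 to compound 4 (0.21 log units; within the scatter) expected to stay within the scatter. Compound 4 is estimated to give 130000 nM in this assay, within a range from 50000 nM to 300000 nM.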

Compound 4, half-maximal inhibitory concentration: 238000 nM
For compound 4 the middle estimate is 1.8-fold (0.26 log units) below the measured one; the range from low to high includes it.
By their numbers in this assay, from the lowest: compound 3; then compounds 1, 2 and 4 (each within the scatter of the next, the first and the last beyond it).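

Lengthening the methoxy group to 2-methoxyethoxy is a change that this assay does not resolve, with a 1.1-fold higher number from compound 2 to compound 4 (0.05 log units; within the scatter), so this position accepts the added methoxymethyl without a readable shift. Compound 1 and compound 4 do separate, with a 2.2-fold higher number from compound 1 to compound 4 (0.35 log units; beyond the scatter), but this step is modest and compound 2 cannot be told apart from either of them. The larger contrast remains between the ether chains and the amine, with a 17-fold higher number from compound 3 to compound 4 (1.22 log units; beyond the scatter), so the added chain length brings compound 4 no closer to the diethylamino compound.

On these data alone, whether a smaller amine such as dimethylamino, a ring amine such as morpholine or a carboxylic acid at this position would give a lower or higher number remains open. No measurement shown here explains the difference between the ethers and the amine.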